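This account rests on a few compounds, and the source may have more. Where it says the series, first, only, none or still open, it means among the compounds named here.

The shared core is shown by compound 1 `COc1ccc(-c2[nH]c3ccc(F)cc3c2C=O)cc1`, which in a functional assay on MCF7 cells (Homo sapiens) for antiproliferative activity, with a stated time of 5 days (on this read-out lower numbers stand for stronger inhibition and higher numbers for weaker inhibition), gives 240 nM. Compound 2 `COc1ccc(-c2[nH]c3ccc(C(C)C)cc3c2C=O)cc1` carries isopropyl in place of fluoro on an aromatic carbon; in this assay compound 2 gives 97 nM, and a 2.5-fold lower number from compound 1 to compound 2 (0.39 log units; beyond the scatter). Compound 3 `COc1ccc(-c2[nH]c3ccc(CC(C)C)cc3c2C=O)cc1` carries isobutyl in place of fluoro on an aromatic carbon; in this assay compound 3 gives 180 nM. Going by the values given here, on the numbers so far compound 3 sits within the usual scatter of both other compounds: a 1.3-fold lower number from compound 1 to compound 3 (0.12 log units; within the scatter), and a 1.9-fold higher number from compound 2 to compound 3 (0.27 log units; within the scatter).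

The next compound, compound 4 `CCCCCc1ccc2[nH]c(-c3ccc(OC)cc3)c(C=O)c2c1`, differs from compound 3 by butyl in place of isopropyl on a saturated chain carbon bound to an aromatic carbon. Among the compounds with values here, no measured step covers butyl. Within the data shown here, the only step beyond the scatter, a 2.5-fold lower number from compound 1 to compound 2 (0.39 log units; beyond the scatter), concerns isopropyl in place of fluoro; the chain change from isopropyl to isobutyl, a 1.9-fold higher number from compound 2 to compound 3 (0.27 log units; within the scatter), stayed within the scatter, so a further change of the chain is not expected to move the number in this assay beyond the scatter in either direction. Compound 4 is therefore expected to give about 180 nM in this assay, with a range of 80 nM to 400 nM. This amounts to an expected no change at the digits printed from compound 3 to compound 4 (within the scatter).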

Compound 4, half-maximal inhibitory concentration: 20 nM
Beside the measured number, compound 4's estimate is 9.0-fold (0.95 log units) above it, outside the stated range (below it).
By their numbers in this assay, from the lowest: compound 4; then compounds 2, 3 and 1 (each within the scatter of the next, the first and the last beyond it).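

In this assay, this position responds strongly to the change of chain: butyl in place of isopropyl on a saturated chain carbon bound to an aromatic carbon gives a 9.0-fold lower number from compound 3 to compound 4 (0.95 log units; beyond the scatter), whereas the earlier change from isopropyl to isobutyl stayed within the scatter. The pentyl chain also separates clearly from the other two groups, with a 4.9-fold lower number from compound 2 to compound 4 (0.69 log units; beyond the scatter) and a 12-fold lower number from compound 1 to compound 4 (1.08 log units; beyond the scatter), so compound 4 alone lies beyond the scatter of every other compound shown. Nothing available explains this shift.

The step from isobutyl to pentyl adds length and removes the branch at once, so the compounds shown do not separate these two changes. On these data alone, whether a longer chain such as hexyl or octyl, or a pentyl chain ending in an amine or a carboxylic acid, would hold this number remains open.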